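From compound 2 to compound 4: an amide group swap

The source may report more compounds than this note shows. Statements on the series, on what has been measured and on what is new or still open speak of the compounds shown alone.

Working notes on three compounds read in a functional assay on KB cells (Homo sapiens) for antiproliferative activity, read by sulforhodamine B assay, with a stated time of 3 days; on this read-out higher numbers stand for weaker inhibition of growth and lower numbers for stronger inhibition of growth. Among the compounds with values here, compound 1 `COc1ccc(N2CCN(C)CC2)cc1Nc1ncc(F)c(Nc2ccc(F)cc2)n1` gives 960 nM, the only true number so far. Compound 2 `COc1ccc(NC(=O)c2cccc(Nc3ncc(F)c(Nc4ccc(F)cc4)n3)c2)cc1` stands at > 10000 nM, which is a limit of this assay and not a number. Compound 3 `CN(C)c1ccc(C(=O)Nc2cccc(Nc3ncc(F)c(Nc4ccc(F)cc4)n3)c2)cc1` stands at > 10000 nM, also a limit. The picture at the weak end is therefore (the limit of > 10000 nM in this assay, at which 2 of the 3 values shown sit). Compound 2 has no exact position, and any step from it can only be judged against that limit.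

Compound 4 `Cn1ccnc1NC(=O)c1cccc(Nc2ncc(F)c(Nc3ccc(F)cc3)n2)c1` has 1-methyl-1H-imidazol-2-yl in place of 4-methoxyphenyl on an amide-type nitrogen.

Within the data shown here, no measured step covers this change. The expectation in this assay is therefore no step beyond the scatter, with a small shift towards stronger inhibition of growth possible. This expectation leans on compound 3, a second amide whose > 10000 nM is likewise a limit. The expected change is a number no higher from compound 2 to compound 4 (the limit leaves the size open). Another limit reading is the likelier outcome for compound 4. For compound 4 the estimated value is 10000 nM, with an expected range from 3000 nM to 30000 nM.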

Compound 4, concentration for 50% growth inhibition: 14600 nM
Beside the measured number, compound 4's estimate is 1.5-fold (0.16 log units) below it, and the stated range covers the measured number.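

In this assay compound 4 gives 14600 nM. Compound 2 stands at > 10000 nM, which is a limit and not a number, so no step from compound 2 to compound 4 can be read: the limit of > 10000 nM in this assay, at which 2 of the 4 values shown sit.

The compounds shown leave open how 1-methyl-1H-imidazol-2-yl and 4-methoxyphenyl on an amide-type nitrogen compare in size of effect.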